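The source may hold more compounds than are shown below. What is called first, only, known or untested is meant among the compounds shown, and "the series" means these compounds.

Of the compounds shown here, two sharing one core have so far been tested in a functional assay on HOP-92 cells (Homo sapiens) for cytotoxicity, read by sulforhodamine B assay, with a stated time of 48 h; a lower number here means a stronger inhibitor of growth, a higher number a weaker inhibitor of growth. Compound 1 `CC1=C(C(=O)Nc2ccc(Cl)c(Cl)c2)C(c2cccc(Oc3ccccc3)c2)NC(=S)N1` gives 13200 nM in this assay, the lower of the two numbers. Compound 2 `CC1=C(C(=O)Nc2ccc(F)c(Cl)c2)C(c2ccccc2Cl)NC(=S)N1` gives 50100 nM in this assay, and the gap between compound 1 and compound 2 lies beyond the usual scatter. Compound 3 `COc1cccc(C2NC(=S)NC(C)=C2C(=O)Nc2ccc(Cl)c(Cl)c2)c1` has not yet been measured in this assay. It differs from compound 1 in one place only: methyl in place of phenyl on an oxygen on an aromatic ring. Within the data shown here, no single-change step between measured compounds is known, so the effect of trading phenoxy for methoxy rests on no earlier number. The step of a 1.4-fold higher number from compound 1 to compound 3 (0.13 log units; within the scatter) is expected to be modest, most likely within the scatter or a slight weakening, since compound 1 at 13200 nM is the only anchor. Compound 3 is therefore estimated at 18000 nM, with a range from 6000 nM to 55000 nM.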

Compound 3, concentration for 50% growth inhibition: 12600 nM
For compound 3 the middle estimate is 1.4-fold (0.15 log units) above the measured one, within the range that was stated.
By their numbers in this assay, from the lowest: compounds 3 and 1 (each within the scatter of the next); then compound 2.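

In this assay, the change of phenyl to methyl on an oxygen on an aromatic ring gives a 1.0-fold lower number from compound 1 to compound 3 (0.02 log units; within the scatter), the first single-change step known on this core. It shows that at this place the ring of six carbons can give way to a single carbon with no change beyond the scatter, so the phenyl of the phenoxy group is not required for the level of growth inhibition seen here. No measurement at hand explains why the two groups read alike.

The compounds shown leave open whether anything on that oxygen matters in this assay, as a free hydroxyl, a longer chain such as butoxy or an amine in place of methoxy would show. They also leave open whether this flat step would hold with the other ring substitution of compound 2, which differs from compound 3 in more than one place.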